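The compounds below may be only part of what the source reports. "The series", "measured", "known", "first", "only" and "open" are said of these compounds alone.

Measured in a functional assay on HeLa cells (Homo sapiens) for cytotoxicity, read by WST assay, with a stated time of 48 h; a lower number here means a stronger inhibitor, a higher number a weaker inhibitor:
- compound 1 `COc1ccc([C@H](O)[C@H]2CO[C@@H](c3ccc(OC)c(OC)c3)[C@H](C/C=C/c3ccccc3)C2)cc1OC`: 16100 nM
- compound 2 `Oc1ccccc1/C=C/C[C@H]1C[C@@H]([C@@H](O)c2ccccc2)CO[C@@H]1c1ccccc1`: 21800 nM
- compound 3 `COc1ccc([C@H](O)[C@H]2CO[C@H](c3ccc(OC)c(OC)c3)[C@@H](C/C=C/c3ccc(OC)c(OC)c3)C2)cc1`: 46000 nM

Compound 2, at 21800 nM, lies within the scatter of compound 1, while compound 3 gives a higher number, beyond the scatter. All three values are weak on this scale.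

Compound 4 `COc1ccccc1/C=C/C[C@H]1C[C@@H]([C@@H](O)c2ccccc2)CO[C@@H]1c1ccccc1` departs from compound 2 by methyl in place of hydrogen on an oxygen on an aromatic ring. This is methyl in place of hydrogen on an oxygen on an aromatic ring, turning 2-(2-hydroxyphenyl)ethenyl into 2-(2-methoxyphenyl)ethenyl.

Going by the values given here, no measured pair isolates this change. Compound 1 and compound 3 carry methoxy groups, but they also differ from compound 2 in other places, so they offer only a loose guide. In this assay, no step beyond the scatter is expected, and any drift is expected to be towards a slightly higher number. The expected step is a 1.1-fold higher number from compound 2 to compound 4 (0.06 log units; within the scatter).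

For compound 4 the estimated value is 25000 nM, with an expected range of 11000 nM to 55000 nM.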

Compound 4, half-maximal inhibitory concentration: 14700 nM
For compound 4 the middle estimate is 1.7-fold (0.23 log units) above the measured one, and the stated range covers the measured number.
By their numbers in this assay, from the lowest: compounds 4, 1 and 2 (each within the scatter of the next); then compound 3.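

In this assay, going by these compounds alone, methyl in place of hydrogen on this oxygen on an aromatic ring, turning 2-hydroxyphenyl into 2-methoxyphenyl, gives a 1.5-fold lower number from compound 2 to compound 4 (0.17 log units; within the scatter) and is the first single-place step. At this position, the hydroxy hydrogen is therefore not required for a number in this range: compound 2 and compound 4 cannot be told apart in this assay. No measurement available here bears on the reading of this step.

Still open, on these data alone, is whether a larger group on this oxygen, such as an ethyl or a longer chain, or an amine in place of the hydroxy, would stay within the scatter of compound 2. Also open, as far as these compounds go, is whether the same hydroxy to methoxy change reads alike on the cores of compound 1 and compound 3.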